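Swapping the Pyridine Headgroup in Two Related Series

The compounds below may be only part of what the source reports. "The series", "measured", "known", "first", "only" and "open" are said of these compounds alone.

Compound 1 `COc1cc(F)c(NC(=O)c2ccnc(Cl)c2)cc1Nc1nccc(-c2cn(C)c3ccccc23)n1` and compound 2 `COc1cc(F)c(NC(=O)c2ccncc2OC)cc1Nc1nccc(-c2cn(C)c3ccccc23)n1` share one core and differ only at the amide: 3-methoxypyridin-4-yl in place of 2-chloropyridin-4-yl on a carbonyl carbon. In a functional assay on NCI-H1975 cells (Homo sapiens) for antiproliferative activity, read by MTT assay, with a stated time of 72 h (a lower number here means a stronger inhibitor, a higher number a weaker inhibitor), compound 1 gives 4330 nM, and compound 2 gives 4120 nM, so the change made a 1.1-fold lower number from compound 1 to compound 2 (0.02 log units; within the scatter). Compound 3 `COc1cc(N(C)CCN(C)C)c(NC(=O)c2ccnc(Cl)c2)cc1Nc1nccc(-c2cn(CCCO)c3ccccc23)n1` carries the same 2-chloropyridin-4-yl amide on a different core; how the two cores differ is not broken down here. In this assay compound 3 gives 1820 nM, the lowest of the three numbers, and its gap to compound 2 and to compound 1 lies beyond the usual scatter. Compound 4 `COc1cc(N(C)CCN(C)C)c(NC(=O)c2ccncc2OC)cc1Nc1nccc(-c2cn(CCCO)c3ccccc23)n1` has not yet been measured. It differs from compound 3 by the same change seen between compound 1 and compound 2, at the same place: 3-methoxypyridin-4-yl in place of 2-chloropyridin-4-yl on a carbonyl carbon. Since that change earlier made a 1.1-fold lower number from compound 1 to compound 2 (0.02 log units; within the scatter), a step of similar size is expected here, a 1.1-fold lower number from compound 3 to compound 4 (0.03 log units; within the scatter). Compound 4 is therefore estimated at 1700 nM in this assay, with a likely range from 800 nM to 3600 nM.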

Compound 4, half-maximal inhibitory concentration: 1970 nM
Beside the measured number, compound 4's estimate is 1.2-fold (0.06 log units) below it; the measured number falls inside the stated range.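

On the second core, in this assay, putting 3-methoxypyridin-4-yl in place of 2-chloropyridin-4-yl gives a 1.1-fold higher number from compound 3 to compound 4 (0.03 log units; within the scatter), so this pair cannot be told apart in this read-out. Set beside the same swap on the first core, the result carries over, in the sense that neither step can be told from the scatter and the two steps agree: the same change on two cores in this assay, a 1.1-fold lower number (0.02 log units; within the scatter) from compound 1 to compound 2 and a 1.1-fold higher number (0.03 log units; within the scatter) from compound 3 to compound 4, 1.1-fold (0.06 log units) apart, within the scatter of two such steps. This shows that the two headgroups are interchangeable in this assay on these two cores only; it does not show that the same would hold on any other core, and it gives no reason why the two read alike.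

The compounds shown leave open what an amine or a longer alkoxy chain such as ethoxy, in place of the chlorine or the methoxy, would do to the pyridine amide on either core. They also leave open which of the several parts that differ between the two cores matters for the antiproliferative number.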